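Quinoxaline hydrazones: bromophenyl variant of compound 1

This account rests on a few compounds, and the source may have more. Where it says the series, first, only, none or still open, it means among the compounds named here.

Among the measured compounds shown here, compound 1 `COc1ccc(/C=N/Nc2nc3ccccc3nc2Cc2ccccc2)cc1OC` gives 56 nM in an assay on isolated protein for inhibition of Amine oxidase [flavin-containing] A (Homo sapiens), read by spectrophotometry (a lower number here means a stronger inhibitor, a higher number a weaker inhibitor), the second highest of the three numbers so far. Compound 2 `C/C(=N\Nc1nc2ccccc2nc1Cc1ccccc1)c1cccs1` gives 64 nM, within the scatter of compound 1, while compound 3 `O=[N+]([O-])c1ccc(/C=N/Nc2nc3ccccc3nc2Cc2ccccc2)cc1` gives 8.8 nM. For the measured compounds named here, the one step with a single change, a 6.4-fold lower number from compound 1 to compound 3 (0.80 log units; beyond the scatter), shows that swapping the aryl group on this carbon can move the number by a modest amount. Compound 4 `Brc1cccc(/C=N/Nc2nc3ccccc3nc2Cc2ccccc2)c1` carries a different aryl group again: 3-bromophenyl in place of 3,4-dimethoxyphenyl on a carbon with a double bond to nitrogen. Going by the values given here, no measured step covers a bromophenyl, so the 1-to-3 step is the only guide, and its direction is followed with less confidence. For compound 4 the estimate is a step of a 1.9-fold lower number from compound 1 to compound 4 (0.27 log units; within the scatter), expected to land at 30 nM, with a range from 10 nM to 90 nM.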

Compound 4, half-maximal inhibitory concentration: 9.8 nM
Compound 4: the middle estimate sits 3.1-fold (0.49 log units) above what was measured; measured number outside the range, below it.
By their numbers in this assay, from the lowest: compounds 3 and 4 (each within the scatter of the next); then compounds 1 and 2 (each within the scatter of the next).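

In this assay, the 3-bromophenyl group gives a 5.7-fold lower number from compound 1 to compound 4 (0.76 log units; beyond the scatter), so a second aryl group on this carbon also moves the number by a modest amount, and a 1.1-fold higher number from compound 3 to compound 4 (0.05 log units; within the scatter), leaving 3-bromophenyl and 4-nitrophenyl indistinguishable here. The change of the whole group on the aromatic-ring nitrogen gives a 6.5-fold lower number from compound 2 to compound 4 (0.81 log units; beyond the scatter), a step that cannot be assigned to any single part of that group. Nothing available bears on the reason for these shifts. Still open, from the compounds shown here alone, is how a plain phenyl, or an aryl group carrying an amine or a carboxylic acid, would compare with compound 4.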